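The compounds below may be only part of what the source reports. "The series", "measured", "known", "first", "only" and "open" are said of these compounds alone.

Compound 1 `C[C@@H](O)[C@H]1C(=O)N2C(C(=O)OCOC(=O)C(C)(C)C)=C(S[C@@H]3CN[C@H](C(=O)Nc4cccc(C(=O)O)c4)C3)[C@H](C)[C@H]12` in an ADME assay for metabolic stability, read by LC-MS, with a stated time of 3 h, at pH 6.5, tested at 50 uM (a lower number here means that less of the compound is left, a higher number that more of the compound is left), gives > 95%, which is a limit of the assay rather than a number.
Compound 2 `CC(OC(=O)C1=C(S[C@@H]2CN[C@H](C(=O)Nc3cccc(C(=O)OC(C)OC(=O)C(C)(C)C)c3)C2)[C@H](C)[C@@H]2[C@@H]([C@@H](C)O)C(=O)N12)OC(=O)C(C)(C)C` in this assay gives > 95%, also a limit of the assay.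

Among the measured compounds shown here, compound 1 thus stands at the upper limit of what this assay can report, and the same holds for every value so far (the limit of > 95% in this assay, at which 2 of the 2 values shown sit). Compound 3 `C[C@@H](O)[C@H]1C(=O)N2C(C(=O)OCOC(=O)C3CCCCC3)=C(S[C@@H]3CN[C@H](C(=O)Nc4cccc(C(=O)O)c4)C3)[C@H](C)[C@H]12` differs from compound 1 by cyclohexyl in place of tert-butyl on a carbonyl carbon. For the measured compounds named here, no measured step is available, so the change is expected to be a number at least 3 percentage points lower from compound 1 to compound 3 (that floor lies within the scatter), none beyond the scatter, with compound 3 most likely again close to the limit. The estimate for compound 3 is 92%, in a range from 75% to 99%.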

Compound 3, percent of the compound remaining: > 95%
Compound 3 gave a limit, no number; the forecaster's own chance of this, stated with the estimate: 60%; at least 3 percentage points between middle value and limit.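

In this assay compound 3 gives > 95% and this is a limit, not a number. Among the compounds shown here, compound 1 sits at the same limit, so no step between compound 1 and compound 3 can be read. The compounds shown leave open whether cyclohexyl and tert-butyl on this carbonyl carbon differ at all, because every value stands at one limit: the limit of > 95% in this assay, at which 3 of the 3 values shown sit.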